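Turning one ring stereocentre in a potent pair

The source may report more compounds than this note shows. Statements on the series, on what has been measured and on what is new or still open speak of the compounds shown alone.

- compound 1 `CC1=C(c2cccc(O)c2)C(c2ccc(OC[C@@H](C)N3CCCC3)cc2)Oc2ccc(O)cc21`: 0.2 nM
- compound 2 `CC1=C(c2cccc(O)c2)C(c2ccc(OC[C@H](C)N3CC[C@@H](C)C3)cc2)Oc2ccc(O)cc21`: 0.2 nM

In a functional assay on MCF7 cells (Homo sapiens) for antiproliferative activity, read by CellTiter-Glo, with a stated time of 5 days (a higher number here means a weaker inhibitor, a lower number a stronger inhibitor), compound 2 stands level with compound 1. Compound 3 `CC1=C(c2cccc(O)c2)C(c2ccc(OC[C@H](C)N3CC[C@H](C)C3)cc2)Oc2ccc(O)cc21` follows from compound 2 through the two compounds have the same atoms and bonds; at least one stereo element is drawn with a configuration in one of them and without one in the other: 1 of 3 stereo elements differ; a stereocentre at a saturated ring carbon is drawn R in compound 2 and S in compound 3: a stereocentre at a saturated ring carbon is drawn R in compound 2 and S in compound 3. Going by the values given here, the only measured step, no change at the digits printed from compound 1 to compound 2 (within the scatter), put a larger group in place of a smaller one and did not test this stereocentre, so it is thin guidance. Going by that step, no change beyond the scatter is expected in this assay. For compound 3 the estimated value is 0.3 nM, with an expected range of 0.1 nM to 1 nM. This estimate means an expected 1.5-fold higher number from compound 2 to compound 3 (0.18 log units; within the scatter).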

Compound 3, half-maximal inhibitory concentration: 0.2 nM
For compound 3 the middle estimate is 1.5-fold (0.18 log units) above the measured one; low and high end bracket the measured number.
By their numbers in this assay, from the lowest: compounds 1, 2 and 3 (each within the scatter of the next).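

Turning the stereocentre at the saturated ring carbon from R to S gives no change at the digits printed from compound 2 to compound 3 (within the scatter) in this assay, so this assay does not separate these two drawn forms. Placing the group of 8 heavy atoms where the group of 7 stood likewise gives no change at the digits printed from compound 1 to compound 3 (within the scatter), now for the second drawn form as well. One caution applies to the stereo comparison: the fact that one of compounds 2 and 3 is drawn with a defined configuration and the other without, at the place where they differ

From the compounds shown here alone, whether this stereocentre would matter with an ethyl or phenyl group on that ring carbon stays open. So does the effect of a six-membered piperidine ring in place of the five-membered ring.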